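A Methoxyphenyl Swap on a Shared Core

The source may hold more compounds than are shown below. What is called first, only, known or untested is meant among the compounds shown, and "the series" means these compounds.

In a functional assay on SGC-7901 cells (Homo sapiens) for antiproliferative activity, read by sulforhodamine B assay, with a stated time of 72 h (a lower number here means a stronger inhibitor, a higher number a weaker inhibitor), compound 1 (`S=C(NCc1ccccc1)N/N=C/c1ccc2ccccc2n1`) gives 53700 nM, and compound 2 (`Fc1cccc(NC(=S)N/N=C/c2ccc3ccccc3n2)c1`) gives 79900 nM. Only these two numbers are known so far, and compound 2 stands level with compound 1 within the usual scatter of repeat measurements. Compound 3 (`COc1ccc(NC(=S)N/N=C/c2ccc3ccccc3n2)cc1`) keeps the shared core but carries 4-methoxyphenyl in place of 3-fluorophenyl on an amide-type nitrogen. Going by the values given here, one measured step bears on this change, since it altered the group on the same nitrogen, replacing benzyl with 3-fluorophenyl: a 1.5-fold higher number from compound 1 to compound 2 (0.17 log units; within the scatter). Among the compounds with values here, that single step stayed within the scatter, and no measured compound yet carries 4-methoxyphenyl, so no clear shift is expected in this assay. The expected step, no larger than the scatter, is a 1.2-fold lower number from compound 2 to compound 3 (0.09 log units; within the scatter). Compound 3 is expected to give 65000 nM, with an estimated range from 28000 nM to 130000 nM.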

Compound 3, half-maximal inhibitory concentration: 89600 nM
Estimate against measurement, compound 3: 1.4-fold (0.14 log units) below; the measured number falls inside the stated range.
By their numbers in this assay, from the lowest: compounds 1, 2 and 3 (each within the scatter of the next).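

On the amide-type nitrogen, swapping 3-fluorophenyl for 4-methoxyphenyl gives a 1.1-fold higher number from compound 2 to compound 3 (0.05 log units; within the scatter) in this assay, and swapping benzyl for 4-methoxyphenyl gives a 1.7-fold higher number from compound 1 to compound 3 (0.22 log units; within the scatter) in the same test. Although 4-methoxyphenyl brings a hydrogen-bond acceptor that 3-fluorophenyl lacks, benzyl, 3-fluorophenyl and 4-methoxyphenyl cannot be told apart here, so these numbers show no preference among the three groups at this position. No supporting measurement is available to explain this result.

Going by these compounds, it remains open whether any group on this nitrogen can move the number beyond the scatter, for example an amine, a carboxylic acid or a longer chain. On these data alone, all three compounds also share the same core, so the effect of changes elsewhere in the molecule remains unknown.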